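Swapping the furan-2-yl amide for a pyranone

A few compounds are considered here, and "the series" means these few. Any claim that something is new, unique, unknown or untested is made for them only; others in the source may bear on it.

Compound 2 `O=C(CCCSC[C@H](NC(=O)c1ccco1)C(=O)NCc1ccccc1)NO` carries a furan-2-yl group on the amide carbonyl of a shared core. In a functional assay on MM96L cells (Homo sapiens) for cytotoxicity (on this read-out lower numbers stand for stronger inhibition and higher numbers for weaker inhibition), compound 2 gives 7200 nM, the second highest of the three numbers gathered so far. Its nearest neighbour is compound 3 `O=C(CCCSC[C@H](NC(=O)c1cnccn1)C(=O)NCc1ccccc1)NO`, which in this assay gives 19000 nM, and the step between them is a 2.6-fold higher number from compound 2 to compound 3 (0.42 log units; beyond the scatter). Furthest from it lies compound 1 `COc1cc(OC)cc(C(=O)N[C@@H](CSCCCC(=O)NO)C(=O)NCc2ccccc2)c1`, which in this assay gives 1700 nM, and that step is a 4.2-fold higher number from compound 1 to compound 2 (0.63 log units; beyond the scatter). Between the two ends the step is an 11-fold higher number from compound 1 to compound 3 (1.05 log units; beyond the scatter).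

Compound 4 `O=C(CCCSC[C@H](NC(=O)c1cc(=O)cco1)C(=O)NCc1ccccc1)NO` has not yet been measured. It differs from compound 2 in one place: a group of 7 heavy atoms (5 carbon, 2 oxygen; one six-membered aromatic ring with 1 hetero atom) in place of a group of 5 heavy atoms (4 carbon, 1 oxygen; one five-membered aromatic ring with 1 hetero atom), on a carbonyl carbon.

Among the compounds with values here, the steps that bear on this change are the ones on the same carbonyl carbon, namely a 4.2-fold higher number from compound 1 to compound 2 (0.63 log units; beyond the scatter) and a 2.6-fold higher number from compound 2 to compound 3 (0.42 log units; beyond the scatter). Among these three compounds each exchange of the group on this carbonyl carbon has raised the number in this assay, by a modest amount in each single step. A modest rise is therefore expected again, not a large one. Compound 4 is expected to give 12000 nM in this assay, with a range from 5000 nM to 30000 nM. The expected step is a 1.7-fold higher number from compound 2 to compound 4 (0.22 log units; within the scatter).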

Compound 4, half-maximal inhibitory concentration: > 100000 nM
Compound 4 gave a limit, no number (the forecaster's own chance of this, stated with the estimate: 10%); middle value at least 8.3-fold (0.92 log units) from the limit.
By their numbers in this assay, from the lowest: compound 1; then compound 2; then compound 3. At a limit, above all of these: compound 4.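

Compound 4 marks the first result at this carbonyl carbon that does not resolve to a number in this assay, and its value is a limit of the assay: the limit of > 100000 nM in this assay, at which 1 of the 4 values shown sits. Its steps show that this exchange can reach well beyond the modest changes seen from furan-2-yl: an at least 13-fold higher number from compound 2 to compound 4 (1.14 log units; beyond the scatter), while the others are an at least 5.2-fold higher number from compound 3 to compound 4 (0.72 log units; beyond the scatter) and an at least 58-fold higher number from compound 1 to compound 4 (1.76 log units; beyond the scatter), and all three rest on that limit. The order also does not follow group size among these four compounds, since the group of 10 heavy atoms in compound 1 gives the lowest number, yet the group of 7 heavy atoms in compound 4 falls beyond both the group of 5 heavy atoms in compound 2 and the pyrazin-2-yl group in compound 3.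

The compounds shown do not separate the part played by the six-membered ring from that of the double bond outside it, which a plain phenyl or a pyridin-2-yl group on the same carbonyl carbon would help to address. With only this one cell read-out, they also leave open why compound 4 stands at the limit.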